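This account rests on a few compounds, and the source may have more. Where it says the series, first, only, none or still open, it means among the compounds named here.

Measured so far in an assay on isolated protein for binding affinity to Sigma non-opioid intracellular receptor 1 (Homo sapiens); on this read-out lower numbers stand for stronger inhibition and higher numbers for weaker inhibition:
compound 1, `OC1CCNC(C2COC(c3ccccc3)(c3ccccc3)O2)C1`, at > 800 nM, a limit of the assay
compound 2, `FC1(F)CCNC(C2COC(c3ccccc3)(c3ccccc3)O2)C1`, at > 800 nM, a limit of the assay

Neither reading is a number. For compound 1 the value > 800 nM is a limit of the assay. For compound 2 the value > 800 nM is likewise a limit, so compound 2 stands at the limit of this assay and no number is known for it. Going by the values given here, the one measured step, a step that the two limits leave unreadable from compound 1 to compound 2, cannot be read because the limit of > 800 nM in this assay, at which 2 of the 2 values shown sit, holds both of its ends.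

Compound 3, `FC1CCNC(C2COC(c3ccccc3)(c3ccccc3)O2)C1`, differs from compound 2 by hydrogen in place of fluoro on a saturated ring carbon. Among the compounds with values here, no measured step covers this change; the single step on record bears on it only in that both of its ends sit at the limit. In this assay, therefore, no step beyond the scatter is expected in either direction, and the expectation is that compound 3 again reaches only the limit. The estimate for compound 3 in this assay is 1500 nM, with a range from 400 nM to 6000 nM. The expected step that the limit leaves unreadable from compound 2 to compound 3 is thus taken as nil within the scatter.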

Compound 3, inhibition constant: > 800 nM
Compound 3 ended at the assay's limit; the forecaster's own chance of this, stated with the estimate: 70%; the middle value is on the limit's open side.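

In this assay compound 3 gives > 800 nM, which is a limit of the assay. Going by these compounds alone, no step among compound 1, compound 2 and compound 3 can be read: the limit of > 800 nM in this assay, at which 3 of the 3 values shown sit. The compounds shown leave open whether the 4-hydroxypiperidin-2-yl, 4,4-difluoropiperidin-2-yl and 4-fluoropiperidin-2-yl compounds differ at all in binding affinity.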